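This account rests on a few compounds, and the source may have more. Where it says the series, first, only, none or still open, it means among the compounds named here.

Of the compounds shown here, three of the shared core have been measured in a toxicity assay on L02 cells (Homo sapiens) for cytotoxicity, read by MTT assay, with a stated time of 72 h; on this read-out lower numbers stand for stronger inhibition and higher numbers for weaker inhibition. Compound 1 `O=C1c2c[n+]([O-])c3ccccc3c2C(=O)c2c1c1ccccc1n2Cc1cn([C@H]2O[C@H](CO)[C@@H](O)[C@H]2O)nn1` gives 950 nM. Compound 3 `CC1(C)OC[C@H](Cn2cc(Cn3c4c(c5ccccc53)C(=O)c3c[n+]([O-])c5ccccc5c3C4=O)nn2)O1` gives 470 nM. Compound 2 `CN1CCN(CCCCn2c3c(c4ccccc42)C(=O)c2c[n+]([O-])c4ccccc4c2C3=O)CC1` gives 80 nM, the lowest of the three values, with compound 3 nearest and compound 1 furthest. Within the data shown here, the only recorded single-point step, a 2.0-fold lower number from compound 1 to compound 3 (0.31 log units; beyond the scatter), concerns a change on an aromatic nitrogen and does not touch the chain that carries the 4-methylpiperazin-1-yl group. Compound 4 `CN1CCN(CCCCCn2c3c(c4ccccc42)C(=O)c2c[n+]([O-])c4ccccc4c2C3=O)CC1` differs from compound 2 by (4-methylpiperazin-1-yl)methyl in place of 4-methylpiperazin-1-yl on a saturated chain carbon, four bonds along the chain from an aromatic nitrogen. Among the measured compounds shown here, no measured step bears on lengthening this chain, so for the step of a 1.1-fold higher number from compound 2 to compound 4 (0.05 log units; within the scatter) nothing beyond the scatter is expected in this assay. Compound 4 is therefore estimated at 90 nM, with a range of 40 nM to 200 nM.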

Compound 4, half-maximal inhibitory concentration: 1640 nM
The estimate for compound 4 lay 18-fold (1.26 log units) below the measured number; measured number outside the range, above it.
By their numbers in this assay, from the lowest: compound 2; then compound 3; then compounds 1 and 4 (each within the scatter of the next).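

In this assay, the saturated chain carbon four bonds along the chain from an aromatic nitrogen proves highly sensitive: (4-methylpiperazin-1-yl)methyl in place of 4-methylpiperazin-1-yl gives a 21-fold higher number from compound 2 to compound 4 (1.31 log units; beyond the scatter). The earlier series held only a 2.0-fold lower number from compound 1 to compound 3 (0.31 log units; beyond the scatter), a modest step from a change on an aromatic nitrogen, so this chain extension is the largest single-point change seen so far. No available data account for the step.

As far as these compounds go, whether a longer chain or a shorter chain would continue this direction remains open, as a single step defines no trend. Also open, from the compounds shown here alone, is whether morpholine in place of 4-methylpiperazin-1-yl would matter at either chain length.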